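Chromone ethers with triazolylmethyl side chains: cytotoxicity notes

The source may report more compounds than this note shows. Statements on the series, on what has been measured and on what is new or still open speak of the compounds shown alone.

Measured so far:
- compound 1, `Cc1ccccc1Cn1cc(COc2ccc3c(=O)ccoc3c2)nn1`: reported only as a limit, > 100000 nM
- compound 2, `CC(C)(C)c1ccc(Cn2cc(COc3ccc4c(=O)ccoc4c3)nn2)cc1`: reported only as a limit, > 100000 nM
- compound 3, `C#CCOc1ccc2c(=O)ccoc2c1`: reported only as a limit, > 100000 nM

All three compounds were tested in a functional assay on MDA-MB-231 cells (Homo sapiens) for cytotoxicity, read by MTT assay, with a stated time of 48 h; on this read-out higher numbers stand for weaker inhibition and lower numbers for stronger inhibition. Compound 1 sits at the limit of the assay, not at a number. The same holds for compound 2 and for compound 3, each reported at the limit. Thus the limit of > 100000 nM in this assay, at which 3 of the 3 values shown sit: no measured compound in the set gives a number at all, and no step between measured compounds can be read.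

The next compound, compound 4, `O=c1ccoc2cc(OCc3cn(Cc4ccccc4F)nn3)ccc12`, differs from compound 1 in one place: fluoro in place of methyl on an aromatic carbon. Going by the values given here, with nothing but limits in hand, there is no measured precedent for the size of any step in this assay. The expectation for compound 4 is that the step that the limit leaves unreadable from compound 1 to compound 4 stays within the scatter, that is, no change beyond the scatter, and compound 4 is expected to remain at the limit. The estimate for compound 4 in this assay is 150000 nM, with a range from 30000 nM to 1000000 nM.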

Compound 4, half-maximal inhibitory concentration: 29800 nM
Compound 4: the middle estimate sits 5.0-fold (0.70 log units) above what was measured; the measured number lies below the stated range.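

In this assay, going by these compounds alone, the exchange of 2-methylbenzyl for 2-fluorobenzyl gives an at least 3.3-fold lower number from compound 1 to compound 4 (0.52 log units; beyond the scatter), the first step that can be read at all. This place, on an aromatic carbon of a six-membered aromatic ring of carbon only, ortho to a large group, therefore responds to substitution: one heavy atom exchanged for one heavy atom, with no ring, hydrogen-bond donor, hydrogen-bond acceptor or net charge entering or leaving, is enough to bring a compound of this set off the limit. The step is a lower bound and not a full size, and the true distance from compound 1 stays unknown, as the other values give no number to compare with: the limit of > 100000 nM in this assay, at which 3 of the 4 values shown sit.

Whether the change depends on fluoro itself stays open, since the compounds shown do not tell what chloro, methoxy, a nitrile or a plain hydrogen on the same aromatic carbon would give. Also open, from the compounds shown here alone, is whether an amine or a carboxylic acid on this benzyl ring would move the number further from the limit than compound 4 does.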